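Chloro for fluoro on the pyridine ring: a second instance

A few compounds are considered here, and "the series" means these few. Any claim that something is new, unique, unknown or untested is made for them only; others in the source may bear on it.

Compound 1 `O=S(=O)(/C=C/c1ncccc1F)c1cccc(Cl)c1` and compound 3 `O=S(=O)(/C=C/c1ncccc1F)c1ccc(Cl)cc1` share the same atoms joined differently; the difference between the two cores is not broken down here. In an assay on U2OS cells for activation of nuclear factor erythroid 2-related factor 2 (Homo sapiens), read by beta-arrestin recruitment, with a stated time of 6 h (on this read-out higher numbers stand for an effect only at larger amounts of compound and lower numbers for an effect already at smaller amounts), compound 1 gives 198 nM and compound 3 gives 286 nM, a gap within the scatter. Compound 2 `O=S(=O)(/C=C/c1ncccc1Cl)c1cccc(Cl)c1` carries the change (chloro in place of fluoro on an aromatic carbon), and the step of a 4.3-fold lower number from compound 1 to compound 2 (0.63 log units; beyond the scatter) in this assay gives compound 2 a value of 46 nM. Compound 4 `O=S(=O)(/C=C/c1ncccc1Cl)c1ccc(Cl)cc1` is not yet measured; relative to compound 3 it carries the change (chloro in place of fluoro on an aromatic carbon), the same change at the same place. Within the data shown here, the expected step of a 4.3-fold lower number from compound 3 to compound 4 (0.64 log units; beyond the scatter) in this assay rests on the one measured instance, a 4.3-fold lower number from compound 1 to compound 2 (0.63 log units; beyond the scatter), carried over to compound 3 with its value 286 nM. Compound 4 is therefore estimated at 66 nM, within 30 nM to 150 nM.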

Compound 4, half-maximal effective concentration: 65 nM
Estimate against measurement, compound 4: 1.0-fold (0.01 log units) above, and the stated range covers the measured number.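

In this assay, chloro in place of fluoro on an aromatic carbon gives a 4.4-fold lower number from compound 3 to compound 4 (0.64 log units; beyond the scatter), and the step carries over between the two cores: the same change on two cores in this assay, a 4.3-fold lower number (0.63 log units; beyond the scatter) from compound 1 to compound 2 and a 4.4-fold lower number (0.64 log units; beyond the scatter) from compound 3 to compound 4, 1.0-fold (0.01 log units) apart, within the scatter of two such steps. This supports carrying the change between these two cores, which share the same atoms joined differently, with the change at the same place on the six-membered aromatic ring with 1 nitrogen. It rests on two instances in one assay, so it does not show that the step holds on a core altered in any other way, and it gives no reason for the step.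

From the compounds shown here alone, whether methyl, methoxy or an amine at this place would follow chloro or fluoro remains open. So does the size of the same step on a core carrying a nitrile in place of the chloro on the other aromatic ring.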